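The source may report more compounds than this note shows. Statements on the series, on what has been measured and on what is new or still open speak of the compounds shown alone.

Among the measured compounds shown here, compound 1 `O=C(Nc1cc(C(F)(F)F)cc(C(F)(F)F)c1)c1cc(F)ccc1O` and compound 2 `O=C(Nc1cc(C(F)(F)F)cc(C(F)(F)F)c1)c1cc(Br)ccc1O` share a core that differs from the one in compound 3 `O=C(Nc1ccc(F)c(C(F)(F)F)c1)c1cc(Cl)ccc1O` and compound 4 `O=C(Nc1ccc(Br)c(C(F)(F)F)c1)c1cc(Cl)ccc1O`; how the two cores differ is not broken down here. In an ADME assay on cells (Macrophage, Mus musculus) for cytotoxicity, read by resazurin assay, with a stated time of 3 days (on this read-out higher numbers stand for weaker inhibition and lower numbers for stronger inhibition), compound 1 gives 2500 nM, compound 2 gives 4900 nM, and compound 3 gives 5300 nM. The change from compound 1 to compound 2 is bromo in place of fluoro on an aromatic carbon, and it made a 2.0-fold higher number from compound 1 to compound 2 (0.29 log units; within the scatter). Compound 4 carries the same kind of change, (bromo in place of fluoro on an aromatic carbon), though the place differs: here it sits ortho to a trifluoromethyl group and para to a large group, whereas in compound 2 it sits meta to a large group and para to a hydroxy group. Resting on the single earlier step, compound 4 is expected to show a 1.4-fold higher number from compound 3 to compound 4 (0.15 log units; within the scatter) in this assay. The estimated value of compound 4 is 7500 nM, between 3000 nM and 18000 nM.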

Compound 4, half-maximal inhibitory concentration: 4500 nM
For compound 4 the middle estimate is 1.7-fold (0.22 log units) above the measured one; the measured number falls inside the stated range.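

Putting bromo in place of fluoro on the core of compound 3 gave a 1.2-fold lower number from compound 3 to compound 4 (0.07 log units; within the scatter) in this assay. Set beside the earlier step, the result gives no sign that the core alters the outcome of this change: the same change on two cores in this assay, a 2.0-fold higher number (0.29 log units; within the scatter) from compound 1 to compound 2 and a 1.2-fold lower number (0.07 log units; within the scatter) from compound 3 to compound 4, 2.3-fold (0.36 log units) apart, within the scatter of two such steps. Among the compounds shown here, this shows only that the change stayed within the scatter on both cores; with one pair per core and the change in a different place on each, it does not show that the change would carry over to other cores or places.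

The compounds shown leave open how an amine or a carboxylic acid in that place would read in this assay. They also leave open what replacing the hydroxy group would do on either core.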